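The source may hold more compounds than are shown below. What is called first, only, known or untested is meant among the compounds shown, and "the series" means these compounds.

Compound 1 `N#Cc1ccc(/C=N/NC(=O)Nc2ccc(Oc3ccnc4[nH]ccc34)c(F)c2)cc1` gives the lowest number of the three measured compounds in a functional assay on A549 cells (Homo sapiens) for antiproliferative activity, read by MTT assay, with a stated time of 72 h (a lower number here means a stronger inhibitor, a higher number a weaker inhibitor), at 1360 nM. Compound 2 `O=C(N/N=C/c1ccc(O)cc1)Nc1ccc(Oc2ccnc3[nH]ccc23)c(F)c1` gives 3760 nM, and compound 3 `COc1ccc(/C=N/NC(=O)Nc2ccc(Oc3ccnc4[nH]ccc34)c(F)c2)cc1` gives 3980 nM. Both steps away from compound 1 are modest weakenings: a 2.8-fold higher number from compound 1 to compound 2 (0.44 log units; beyond the scatter) and a 2.9-fold higher number from compound 1 to compound 3 (0.47 log units; beyond the scatter), while a 1.1-fold higher number from compound 2 to compound 3 (0.02 log units; within the scatter). Compound 4 `O=C(N/N=C/c1ccc(O)cc1O)Nc1ccc(Oc2ccnc3[nH]ccc23)c(F)c1` differs from compound 1 by 2,4-dihydroxyphenyl in place of 4-cyanophenyl on a carbon with a double bond to nitrogen. Within the data shown here, the step from compound 1 to compound 2 bears most on this, since it too puts hydroxy in place of cyano; compound 4 carries a second hydroxy, for which no measured step gives a guide. A modest weakening is therefore expected, a 2.9-fold higher number from compound 1 to compound 4 (0.47 log units; beyond the scatter). Compound 4 is estimated at 4000 nM, with a likely range from 1800 nM to 9000 nM.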

Compound 4, half-maximal inhibitory concentration: 5840 nM
Compound 4: the middle estimate sits 1.5-fold (0.16 log units) below what was measured; the range from low to high includes it.
By their numbers in this assay, from the lowest: compound 1; then compounds 2, 3 and 4 (each within the scatter of the next).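

Putting 2,4-dihydroxyphenyl in place of 4-cyanophenyl raises the number in this assay (a 4.3-fold higher number from compound 1 to compound 4 (0.63 log units; beyond the scatter)), so compound 1 remains the strongest of the four. The added hydroxy gives no separable change (a 1.6-fold higher number from compound 2 to compound 4 (0.19 log units; within the scatter)), and neither does replacing 4-methoxyphenyl with 2,4-dihydroxyphenyl (a 1.5-fold higher number from compound 3 to compound 4 (0.17 log units; within the scatter)), so compounds 2, 3 and 4 cannot be told apart here. No measurement shown explains why compound 1 stands apart. On these data alone, it remains open whether the cyano group itself matters, or whether an amine, a carboxylic acid or a trifluoromethyl group in its place would give a similarly low number.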